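A hydroxy side-chain swap on a shared core

The compounds below may be only part of what the source reports. "The series", "measured", "known", "first", "only" and "open" are said of these compounds alone.

Of the compounds shown here, two have been measured on the same core, differing only in the group on a carbonyl carbon whose other neighbour is an amide-type nitrogen. Compound 1 `CC1(C)Cc2c(sc(NC(=O)c3cn[nH]c3)c2C(N)=O)C(C)(C)O1` gives 125 nM in an assay on cells for positive allosteric modulation of Cystic fibrosis transmembrane conductance regulator variant F508del (Homo sapiens), with stated times of 10 min and 7 s, in the presence of a further agent that is not named here; on this read-out lower numbers stand for an effect already at smaller amounts and higher numbers for an effect only at larger amounts of compound. Compound 2 `CC1(C)Cc2c(sc(NC(=O)C3(CO)CC3)c2C(N)=O)C(C)(C)O1` gives 15 nM in this assay, the lower of the two numbers, and the step of an 8.3-fold lower number from compound 1 to compound 2 (0.92 log units; beyond the scatter) separates them. Compound 3 `CC1(C)Cc2c(sc(NC(=O)[C@@H](O)C(C)(C)C)c2C(N)=O)C(C)(C)O1` is not yet measured; it carries the change (1-hydroxy-2,2-dimethylpropyl in place of 1-(hydroxymethyl)cyclopropyl on a carbonyl carbon). Going by the values given here, the one measured step bears only loosely on it, since that step exchanged an aromatic ring for a hydroxy-bearing alkyl group, whereas here one hydroxy-bearing alkyl group gives way to another with the same count of donors and acceptors. A step no larger than the scatter is therefore expected, as a 1.3-fold higher number from compound 2 to compound 3 (0.12 log units; within the scatter). Compound 3 is estimated at 20 nM, within a range from 6 nM to 65 nM.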

Compound 3, half-maximal effective concentration: 2.7 nM
Estimate against measurement, compound 3: 7.4-fold (0.87 log units) above; measured number below the stated range.
By their numbers in this assay, from the lowest: compound 3; then compound 2; then compound 1.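

Exchanging one hydroxy-bearing alkyl group for another on this carbonyl carbon is not a silent change: in this assay, 1-hydroxy-2,2-dimethylpropyl in place of 1-(hydroxymethyl)cyclopropyl gives a 5.6-fold lower number from compound 2 to compound 3 (0.74 log units; beyond the scatter), although both groups have the same counts of hydrogen-bond donors and acceptors. Those counts alone therefore do not set the number at this position, and the open-chain group with its defined stereocentre sits far from the 1H-pyrazol-4-yl group, with a 46-fold lower number from compound 1 to compound 3 (1.67 log units; beyond the scatter). No measurement here accounts for the difference between these groups.

From the compounds shown here alone, whether the defined stereocentre of compound 3 matters remains open, since only one spatial arrangement at that centre appears here. Also open, going by these compounds, is whether the hydroxy group is needed at all, which a plain 2,2-dimethylpropyl group, or an amine in place of the hydroxy, would test.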